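Chloro for ethyl on the anilide ring: cytotoxicity notes

The source may hold more compounds than are shown below. What is called first, only, known or untested is meant among the compounds shown, and "the series" means these compounds.

The series shares one core, seen in compound 1 `CCc1ccc(NC(=O)c2cccc(/C=C3\CC(=O)N(c4ccccc4)C3=O)c2)cc1`. In an ADME assay on HCT-116 cells (Homo sapiens) for cytotoxicity, read by MTT assay, with a stated time of 72 h (a higher number here means a weaker inhibitor, a lower number a stronger inhibitor), compound 1 gives > 100000 nM, which is a limit of the measurement and not a number. Compound 2 `Cc1ccc(N2C(=O)C/C(=C\c3cccc(C(=O)Nc4cccc(F)c4)c3)C2=O)cc1` in this assay gives > 100000 nM, again a limit rather than a number. Among the compounds with values here, compound 3 `CCOc1ccc(NC(=O)c2cccc(/C=C3\CC(=O)N(Cc4ccccc4)C3=O)c2)cc1` is the one compound with a numeric reading and gives 41700 nM in this assay. Within the data shown here, compound 1 therefore stands at the limit of > 100000 nM in this assay, at which 2 of the 3 values shown sit, and no measured step between two compounds is available, so no direction or size for a single change can be read from the data.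

Compound 4 `O=C(Nc1ccc(Cl)cc1)c1cccc(/C=C2\CC(=O)N(c3ccccc3)C2=O)c1` carries chloro in place of ethyl on an aromatic carbon. Nothing measured here speaks to what chloro in place of ethyl does in this assay, so the expectation is no step beyond the scatter: the estimated step from compound 1 to compound 4 is a number no higher from compound 1 to compound 4 (the limit leaves the size open), with the reading most likely to be a limit again. For compound 4 the estimate in this assay is 100000 nM, expected between 40000 nM and 250000 nM, because compound 1 sits at the limit of > 100000 nM in this assay, at which 2 of the 3 values shown sit.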

Compound 4, half-maximal inhibitory concentration: > 100000 nM
Compound 4 ended at the assay's limit; the forecaster's own chance of this, stated with the estimate: 70%; the middle value sits exactly at the limit.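

Compound 1 and compound 4 both read as limits in this assay, not as numbers, so no step for chloro in place of ethyl can be read between them: the limit of > 100000 nM in this assay, at which 3 of the 4 values shown sit.

The compounds shown leave open both the direction and the size of any effect of chloro in place of ethyl on the anilide ring.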